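The source may report more compounds than this note shows. Statements on the series, on what has been measured and on what is new or still open speak of the compounds shown alone.

Measured so far in a functional assay on MV4-11 cells (Homo sapiens) for antiproliferative activity, read by CCK-8 assay, with a stated time of 72 h; on this read-out lower numbers stand for stronger inhibition and higher numbers for weaker inhibition:
- compound 1, `Cn1cc(-c2ccccc2Oc2ccccc2)c2cc(C(=O)NCCCCC(=O)Nc3ccccc3N)[nH]c2c1=O`, gives 240 nM
- compound 2, `Cn1cc(-c2ccccc2Oc2ccccc2)c2cc(C(=O)NCCCCC(=O)NO)[nH]c2c1=O`, gives 180 nM

Compound 2 gives the lowest of the two numbers in this assay, but its nearest neighbour is compound 1, and the gap between them, a 1.3-fold lower number from compound 1 to compound 2 (0.12 log units; within the scatter), is within the scatter, so the two cannot be ranked against each other.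

Compound 3, `Cn1cc(-c2ccccc2Oc2ccccc2)c2cc(C(=O)NCCCCCCC(=O)Nc3ccccc3N)[nH]c2c1=O`, has not yet been measured. It differs from compound 2 in one place: 2-((2-aminophenyl)carbamoyl)ethyl in place of hydroxycarbamoyl on a saturated chain carbon, four bonds along the chain from an amide-type nitrogen. Two things happen at once: the hydroxycarbamoyl head of compound 2 is exchanged for the 2-aminophenyl amide already seen in compound 1, and the saturated chain grows by the ethyl part of the entering group. Only the first part has a measured counterpart, a 1.3-fold lower number from compound 1 to compound 2 (0.12 log units; within the scatter), which is within the scatter. Nothing measured speaks to the longer chain. The step of a 1.4-fold higher number from compound 2 to compound 3 (0.16 log units; within the scatter) is therefore expected to be small and not beyond the scatter. Compound 3 is estimated to give 260 nM in this assay, in a range from 110 nM to 600 nM.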

Compound 3, half-maximal inhibitory concentration: 130 nM
Beside the measured number, compound 3's estimate is 2.0-fold (0.30 log units) above it; the measured number falls inside the stated range.
By their numbers in this assay, from the lowest: compounds 3, 2 and 1 (each within the scatter of the next).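

Among these compounds, compound 1 and compound 3 share the 2-aminophenyl amide head and differ only in chain length, which gives the first measured look at the chain alone. In this assay, the step of a 1.8-fold lower number from compound 1 to compound 3 (0.27 log units; within the scatter) lies within the scatter, so the longer chain brings no change that can be read. Exchanging the hydroxycarbamoyl group (4 heavy atoms, no ring) for 2-((2-aminophenyl)carbamoyl)ethyl (12 heavy atoms, one six-membered aromatic ring) at this place on the chain gives the step of a 1.4-fold lower number from compound 2 to compound 3 (0.14 log units; within the scatter), also within the scatter, and nothing measured here accounts for how close these numbers lie.

The compounds shown leave open whether a still longer or a shorter chain would move the number beyond the scatter. They also leave open what a hydroxycarbamoyl head would give on the longer chain of compound 3, which would separate head from chain in the second step, and what a different head on the same chain, such as a carboxylic acid or a primary amine, would give.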